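This account rests on a few compounds, and the source may have more. Where it says the series, first, only, none or still open, it means among the compounds named here.

Series values in a functional assay on ECa-109 cells for inhibition, with ECa-109 cell line (Homo sapiens) as the target, read by sulforhodamine B assay; a higher number here means a weaker inhibitor, a lower number a stronger inhibitor:
- compound 1 `O=C1C=C(N2CCC2)C(=O)c2c1nc1n2[C@H]2OC[C@@H](O)[C@H]2OC1`: > 16000 nM (a limit)
- compound 2 `O=C1C=C(Nc2cccc(F)c2)C(=O)c2c1nc1n2[C@H]2OC[C@@H](O)[C@H]2OC1`: 7030 nM
- compound 3 `O=C1C(Nc2ccc(C(F)(F)F)cc2)=CC(=O)c2c1nc1n2[C@H]2OC[C@@H](O)[C@H]2OC1`: 2250 nM

Compound 1 is reported only as a limit, > 16000 nM, and not as a number. Of the two exact numbers, compound 2 has the higher, 7030 nM. Compound 3 gives 2250 nM, and that gap to compound 2 lies beyond the scatter.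

Next in the series is compound 4 `COc1ccc(NC2=CC(=O)c3nc4n(c3C2=O)[C@H]2OC[C@@H](O)[C@H]2OC4)cc1`, which has 4-methoxyphenyl in place of 3-fluorophenyl on an amine nitrogen.

Going by the values given here, no measured step exchanges one such aryl group for another. The nearest measured step is an at least 2.2-fold lower number from compound 1 to compound 2 (0.35 log units; beyond the scatter), which puts (3-fluorophenyl)amino in place of azetidin-1-yl. It is a different change and gives only indirect guidance, and its size is open-ended, given (the limit of > 16000 nM in this assay, at which 1 of the 3 values shown sits). The two exact values, compound 2 at 7030 nM and compound 3 at 2250 nM, give the likely span for an arylamino member of this small set.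

In this assay, the expected result is a 1.6-fold lower number from compound 2 to compound 4 (0.19 log units; within the scatter), a small move towards a lower number that is not clearly beyond the scatter. The estimate for compound 4 is 4500 nM, with an expected range of 1500 nM to 13000 nM.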

Compound 4, half-maximal inhibitory concentration: > 4000 nM
Compound 4 ended at the assay's limit; the forecaster's own chance of this, stated with the estimate: 10%; the middle value lies beyond the limit too.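

In this assay compound 4 gives > 4000 nM, a limit and not a number. The steps to compound 4 from compound 2 and from compound 1 cannot be read. The compounds shown leave open whether (4-methoxyphenyl)amino and (3-fluorophenyl)amino differ at all in this read-out, and where compound 4 stands in the series.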